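Cytotoxicity notes on the benzimidazole series, compound 3 to 4

This account rests on a few compounds, and the source may have more. Where it says the series, first, only, none or still open, it means among the compounds named here.

Compound 1 `CN(C)c1cc2[nH]c(C3CCCCC3)nc2cc1NC(=O)OCC(F)(F)F` — > 100 ug/mL
Compound 2 `O=C(CCc1ccccc1)Nc1cc2nc(C3CCCCC3)[nH]c2cc1N1CCCC1` — > 100 ug/mL
Compound 3 `COc1ccc(C(=O)Nc2cc3nc(C4CCCCC4)[nH]c3cc2N2CCCC2)cc1` — > 100 ug/mL

In an ADME assay on Vero cells (Chlorocebus sabaeus) for cytotoxicity, read by resazurin assay, with a stated time of 3 days (on this read-out higher numbers stand for weaker inhibition and lower numbers for stronger inhibition), compound 3 gives > 100 ug/mL, which is a limit of the assay and not a number. Compound 2 likewise gives > 100 ug/mL, a limit. Compound 1 also gives > 100 ug/mL, a limit. All three measured values sit at the limit of > 100 ug/mL in this assay, at which 3 of the 3 values shown sit. Among the compounds with values here, the only step between measured compounds that differ in one place, a step that the two limits leave unreadable from compound 2 to compound 3, is therefore unreadable in size.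

Compound 4 `O=C(Nc1cc2nc(C3CCCCC3)[nH]c2cc1N1CCCC1)OCC(F)(F)F` is not yet measured. Its change from compound 3 is 2,2,2-trifluoroethoxy in place of 4-methoxyphenyl on a carbonyl carbon. Within the data shown here, no measured step bears on this change; the closest comparison is compound 1, which carries the same 2,2,2-trifluoroethoxy carbonyl group and gives > 100 ug/mL, a limit. Given that every value shown sits at the limit of > 100 ug/mL in this assay, at which 3 of the 3 values shown sit, compound 4 is expected to show no step beyond the scatter, a number no higher from compound 3 to compound 4 (the limit leaves the size open). For compound 4 in this assay the estimate is 100 ug/mL, with a range of 50 ug/mL to 200 ug/mL, and the result is most likely to be reported again as a limit.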

Compound 4, half-maximal inhibitory concentration: > 100 ug/mL
Compound 4 was reported as a limit (the forecaster's own chance of this, stated with the estimate: 85%); the middle value sits exactly at the limit.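

In this assay compound 4 gives > 100 ug/mL, a limit of the assay and not a number. Its steps from compound 1, compound 2 and compound 3 cannot be read, as all four compounds share one limit: the limit of > 100 ug/mL in this assay, at which 4 of the 4 values shown sit.

Going by these compounds, whether compound 1, compound 2, compound 3 and compound 4 differ at all in this read-out stays open.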